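The compounds below may be only part of what the source reports. "The series", "measured", "known", "first", "only" and "open" are said of these compounds alone.

Measured in a functional assay on QGY-7703 cells (Homo sapiens) for cytotoxicity, read by MTT assay, with a stated time of 24 h; on this read-out higher numbers stand for weaker inhibition and lower numbers for stronger inhibition:
- Compound 1 `COc1ccc(/C=C2\CN(C)C/C(=C\c3cccnc3)C2=O)c(OC)c1OC`: 2630 nM
- Compound 2 `CN1C/C(=C\c2ccncc2)C(=O)/C(=C/c2ccccc2F)C1`: 4900 nM
- Compound 3 `CN1C/C(=C\c2ccncc2)C(=O)/C(=C/c2ccccc2C(F)(F)F)C1`: 4500 nM

Compound 3, at 4500 nM, lies within the scatter of both other compounds, so these values give no ranking. Compound 4 `O=C1/C(=C/c2ccncc2)CN(S(=O)(=O)c2ccccc2)C/C1=C\c1ccccc1C(F)(F)F` carries phenylsulfonyl in place of methyl on an amine nitrogen in a ring. Within the data shown here, only one measured step bears on this, and only loosely: a 1.1-fold lower number from compound 2 to compound 3 (0.04 log units; within the scatter), a change on an aromatic carbon rather than on the nitrogen. Among the measured compounds shown here, no measured compound varies the group on that nitrogen, so the data fix no direction. A tentative lean towards a lower number in this assay gives an expected step of a 1.8-fold lower number from compound 3 to compound 4 (0.26 log units; within the scatter). Compound 4 is estimated at 2500 nM, with an expected range from 700 nM to 9000 nM.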

Compound 4, half-maximal inhibitory concentration: 6210 nM
Compound 4: the middle estimate sits 2.5-fold (0.40 log units) below what was measured; the range from low to high includes it.
By their numbers in this assay, from the lowest: compounds 1, 3, 2 and 4 (each within the scatter of the next, the first and the last beyond it).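

In this assay, phenylsulfonyl in place of methyl on the amine nitrogen gives a 1.4-fold higher number from compound 3 to compound 4 (0.14 log units; within the scatter), so this first change at that nitrogen cannot be told apart from repeat-measurement noise. Even a much larger group, bringing an aromatic ring of carbon only and hydrogen-bond acceptors, leaves the reading without a detectable shift. No supporting measurement bears on why this is so.

Still open, from the compounds shown here alone, is whether a benzyl group, an acetyl group or a bare hydrogen on that nitrogen would behave alike. One step also cannot show whether the same swap would give a similar result on other compounds with the shared core.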